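Hydrazone with iodinated methoxyphenol: an expected inhibition value

A few compounds are considered here, and "the series" means these few. Any claim that something is new, unique, unknown or untested is made for them only; others in the source may bear on it.

Two hydrazones built on a shared core have been measured so far: compound 1 `O=C(N/N=C/c1ccc(O)c(O)c1)c1ccc(-c2nc3ccccc3s2)cc1` and compound 2 `O=C(N/N=C/c1ccc(O)cc1O)c1ccc(-c2nc3ccccc3s2)cc1`. In an assay on isolated protein for inhibition of Maltase-glucoamylase (Homo sapiens), with a stated time of 15 min (a lower number here means a stronger inhibitor, a higher number a weaker inhibitor), compound 1 gives 15100 nM, while compound 2 gives 5580 nM. The two differ only in the arrangement of hydroxyls on the ring attached to the carbon with a double bond to nitrogen, and the step between them is a 2.7-fold lower number from compound 1 to compound 2 (0.43 log units; beyond the scatter). Within the data shown here, compound 2 therefore holds the lower of the two numbers, with compound 1 as its only neighbour.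

Compound 3 `COc1ccc(/C=N/NC(=O)c2ccc(-c3nc4ccccc4s3)cc2)c(I)c1O` has not yet been measured in this assay. It departs from compound 2 in a single place: 3-hydroxy-2-iodo-4-methoxyphenyl in place of 2,4-dihydroxyphenyl on a carbon with a double bond to nitrogen. Among the measured compounds shown here, the only measured step that bears on this region is the one from compound 1 to compound 2, a modest change obtained by merely moving hydroxyls; the present change is larger, removing one donor and adding iodine and a methoxy, so a step in either direction beyond the scatter is possible, with no clear basis for direction. A slightly weaker result is expected for compound 3, a step of a 1.3-fold higher number from compound 2 to compound 3 (0.13 log units; within the scatter), giving an estimate of 7500 nM within a range from 2000 nM to 30000 nM.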

Compound 3, half-maximal inhibitory concentration: 44800 nM
Beside the measured number, compound 3's estimate is 6.0-fold (0.78 log units) below it, outside the stated range (above it).
By their numbers in this assay, from the lowest: compound 2; then compound 1; then compound 3.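

In this assay, the position on the carbon with a double bond to nitrogen proves able to give a larger shift than the rearrangement of hydroxyls alone suggested: putting 3-hydroxy-2-iodo-4-methoxyphenyl in place of 2,4-dihydroxyphenyl gives an 8.0-fold higher number from compound 2 to compound 3 (0.90 log units; beyond the scatter), against a 2.7-fold lower number from compound 1 to compound 2 (0.43 log units; beyond the scatter) for the earlier pair. The new group also falls on the weaker side of 3,4-dihydroxyphenyl, with a 3.0-fold higher number from compound 1 to compound 3 (0.47 log units; beyond the scatter), so compound 3 has the highest number of the three and both dihydroxyphenyl compounds lie below it, whereas the earlier pair showed only a difference between two hydroxyl arrangements. Nothing available accounts for this rise in the number.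

The entering group brings iodine and methoxy together and rearranges the hydroxyl, so the compounds shown cannot assign the loss to any one of these changes. From the compounds shown here alone, it remains open how a 3-hydroxy-4-methoxyphenyl without the iodine, a plain iodophenyl, or a ring bearing an amine or a carboxylic acid would read at this position on the shared core.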